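Removing a Chloro Group in Two Related Cores

The source may report more compounds than this note shows. Statements on the series, on what has been measured and on what is new or still open speak of the compounds shown alone.

Four compounds are compared here. Compound 1 `Clc1ccc(N2N=NCC2c2ccncc2)cc1` and compound 2 `c1ccc(N2N=NCC2c2ccncc2)cc1` share one core, while compound 3 `Clc1ccc(-n2nncc2-c2cccnc2)cc1` and compound 4 `c1ccc(-n2nncc2-c2cccnc2)cc1` share another; the difference between the two cores is not broken down here.

In a functional assay on the whole organism with Mus musculus as the target (on this read-out lower numbers stand for an effect already at smaller amounts and higher numbers for an effect only at larger amounts of compound), compound 1 gives 43.5 mg/kg, and compound 2 gives 107 mg/kg. Between them lies a single change, (hydrogen in place of chloro on an aromatic carbon), and it brought a 2.5-fold higher number from compound 1 to compound 2 (0.39 log units; beyond the scatter). In this assay compound 3 gives 27 mg/kg. The gap between compound 3 and compound 1 is within the scatter of the measurement, while the gap between compound 3 and compound 2 is beyond it.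

Compound 4 has not yet been measured. It differs from compound 3 by hydrogen in place of chloro on an aromatic carbon, which is the same change that separates compound 1 from compound 2, at the same place in the ring. Among the measured compounds shown here, since only that one measured pair shows this change, and in a different core, the expectation rests on it alone and stays uncertain. The step from compound 3 to compound 4 is expected to be a 2.5-fold higher number from compound 3 to compound 4 (0.40 log units; beyond the scatter), in line with the earlier step of a 2.5-fold higher number from compound 1 to compound 2 (0.39 log units; beyond the scatter). On that basis compound 4 is estimated to give 68 mg/kg in this assay, with a likely range from 35 mg/kg to 130 mg/kg.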

Compound 4, dose for half-maximal effect: 39.7 mg/kg
For compound 4 the middle estimate is 1.7-fold (0.23 log units) above the measured one; the measured number falls inside the stated range.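

On the second core, putting hydrogen in place of chloro gives a 1.5-fold higher number from compound 3 to compound 4 (0.17 log units; within the scatter) in this assay, so on this core alone the swap cannot be told apart from the ordinary spread of repeated measurements. The step on the first core lies beyond the scatter and this one lies within it, yet the two steps cannot be told apart from each other either: the same change on two cores in this assay, a 2.5-fold higher number (0.39 log units; beyond the scatter) from compound 1 to compound 2 and a 1.5-fold higher number (0.17 log units; within the scatter) from compound 3 to compound 4, 1.7-fold (0.22 log units) apart, within the scatter of two such steps. This fits the idea that the change carries over from one core to the other with a similar size, but it does not prove it, since two pairs in a single assay cannot fix the true size of the step on either core, and they say nothing about why the number moves.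

The compounds shown carry only chloro or hydrogen at this place on the ring, which leaves open how a fluoro, a methyl or a methoxy group there would read in this assay. On these data alone, it also remains open whether the same swap would behave alike on a third core, or whether more pairs would separate the two steps that cannot be separated here.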